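The source may report more compounds than this note shows. Statements on the series, on what has been measured and on what is new or still open speak of the compounds shown alone.

The measured compounds in an ADME assay on MT4 cells (Homo sapiens) for cytotoxicity; on this read-out higher numbers stand for lower toxicity in this test and lower numbers for higher toxicity in this test:

Compound 1 `O=C(NNC(=O)c1ccc(Cl)cc1)c1ccncc1` – for compound 1 the read-out is > 120 ug/mL, a limit of the assay rather than a number.
Compound 2 `O=C(N/N=C/c1c[nH]c2ccccc12)c1ccncc1` – compound 2 gives 95 ug/mL.
Compound 3 `COc1cccc(OC)c1/C=N/NC(=O)c1ccncc1` – compound 3 gives 9 ug/mL.

Compound 3 therefore stands lowest of the two numbers; the value of compound 2 lies above it by a gap beyond the scatter, and compound 1 sits at the limit of > 120 ug/mL in this assay, at which 1 of the 3 values shown sits.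

Compound 4 `COc1cccc(OC)c1/C=N/N(C(=O)c1ccccc1)C(=O)c1ccncc1` differs from compound 3 in one place: benzoyl in place of hydrogen on an amide-type nitrogen. For the measured compounds named here, no measured pair shows a change of this kind, so the step of a 1.6-fold higher number from compound 3 to compound 4 (0.19 log units; within the scatter) is expected to be small, in either direction, and likely within the scatter. Compound 4 is estimated at 14 ug/mL, between 4 ug/mL and 60 ug/mL.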

Compound 4, half-maximal cytotoxic concentration: 12 ug/mL
The estimate for compound 4 lay 1.2-fold (0.07 log units) above the measured number; measured number inside the range.
By their numbers in this assay, from the lowest: compounds 3 and 4 (each within the scatter of the next); then compound 2. At a limit, above all of these: compound 1.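

Benzoyl in place of hydrogen on an amide-type nitrogen gives a 1.3-fold higher number from compound 3 to compound 4 (0.12 log units; within the scatter) and so leaves the two compounds indistinguishable in this assay on this read-out. For the compounds shown here, this is the first pair differing in one place, and it shows that this nitrogen can carry benzoyl instead of the amide hydrogen with no step beyond the scatter. Nothing measured here bears on the reason for this result.

From the compounds shown here alone, whether a methyl group, an acetyl group or a chain ending in an amine on this nitrogen would read the same remains open.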